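The source may hold more compounds than are shown below. What is called first, only, known or untested is meant among the compounds shown, and "the series" means these compounds.

Of the compounds shown here, three sharing one core have been tested in a functional assay on BT-474 cells (Homo sapiens) for inhibition, read by fluorescence, with a stated time of 72 h; a higher number here means a weaker inhibitor of growth, a lower number a stronger inhibitor of growth. Compound 1 `CC(C)CCn1cnc2c(Nc3ccccc3)nc(N[C@H]3CC[C@H](N)CC3)nc21` gives 6400 nM in this assay. Compound 2 `CCCCn1cnc2c(Nc3ccc(Cl)cc3)nc(N[C@H]3CC[C@H](N)CC3)nc21` gives 7300 nM in this assay. Compound 3 `CCCCn1cnc2c(Nc3ccccc3)nc(N[C@H]3CC[C@H](N)CC3)nc21` gives 4900 nM in this assay. Compound 3 holds the smallest of the three numbers, yet neither gap means anything on its own: there is a 1.3-fold lower number from compound 1 to compound 3 (0.12 log units; within the scatter), and there is a 1.5-fold lower number from compound 2 to compound 3 (0.17 log units; within the scatter).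

Compound 4 `CCCCn1cnc2c(Nc3cc(OC)cc(OC)c3)nc(N[C@H]3CC[C@H](N)CC3)nc21` is not yet measured. It differs from compound 3 in one place: 3,5-dimethoxyphenyl in place of phenyl on a nitrogen on an aromatic ring. Within the data shown here, of the two measured steps, only the one from compound 2 to compound 3 concerns the ring on that nitrogen, and it stayed within the scatter. The other step alters a saturated chain and says nothing about this ring. So, as far as these data show, replacing one group on this ring with another has not moved the number beyond the scatter, and the expected step is a 1.0-fold higher number from compound 3 to compound 4 (0.01 log units; within the scatter), in effect none that would count. Among the measured compounds shown here, compound 4 is therefore estimated at 5000 nM in this assay, within a range from 1500 nM to 16000 nM, the width reflecting that only a single such ring swap has been observed.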

Compound 4, concentration for 50% growth inhibition: 15600 nM
Compound 4: middle estimate off by 3.1-fold (0.49 log units), on the low side, within the range that was stated.
By their numbers in this assay, from the lowest: compounds 3, 1 and 2 (each within the scatter of the next); then compound 4.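

In this assay, the ring on this nitrogen is no longer a place where swaps leave the number unchanged: 3,5-dimethoxyphenyl in place of phenyl gives a 3.2-fold higher number from compound 3 to compound 4 (0.50 log units; beyond the scatter), so growth inhibition weakens, whereas the earlier swap on this ring, from 4-chlorophenyl to phenyl, stayed within the scatter. The same group also separates from 4-chlorophenyl, with a 2.1-fold higher number from compound 2 to compound 4 (0.33 log units; beyond the scatter), which shows that the result does not depend on phenyl as the point of comparison and that, among these three rings, only 3,5-dimethoxyphenyl stands apart. No measurement at hand bears on what lies behind this rise.

Going by these compounds, with only these three rings compared, it remains open whether one methoxy group on the phenyl would already raise the number or whether the rise needs both. It is also open whether a different group on this ring, such as an amine, a hydroxyl or a carboxylic acid, could take the number below that of compound 3 , since no ring shown so far does so beyond the scatter.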